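The compounds below may be only part of what the source reports. "The series", "measured", "known", "first", "only" and "open" are said of these compounds alone.

Compound 3 `COc1ccc(-c2cc(-c3cc(C(C)C)c(O)cc3C)[nH]c(=O)c2C#N)c(OC)c1` sits second of the three numbers in a functional assay for inhibition, tested at 80 ug/mL; a lower number here means a weaker effect, a higher number a stronger effect of the compound at the concentration tested: compound 3 gives 55%, compound 1 `Cc1cc(O)c(C(C)C)cc1-c1cc(-c2ccccc2)c(C#N)c(=O)[nH]1` gives 58% and compound 2 `COc1cccc(-c2cc(-c3cc(C(C)C)c(O)cc3C)[nH]c(=O)c2C#N)c1` gives 43%. Against compound 1 the gap is a number 3 percentage points lower from compound 1 to compound 3 (within the scatter); against compound 2 it is a number 12 percentage points higher from compound 2 to compound 3 (beyond the scatter). Compound 4 `COc1ccc(-c2cc(-c3cc(C(C)C)c(O)cc3C)[nH]c(=O)c2C#N)cc1` differs from compound 3 by hydrogen in place of methoxy on an aromatic carbon. Going by the values given here, the steps that bear on this are a number 15 percentage points lower from compound 1 to compound 2 (beyond the scatter), where one methoxy entered, and a number 3 percentage points lower from compound 1 to compound 3 (within the scatter), where two entered with little effect. Taking one methoxy away is therefore expected to move this assay little, with any shift toward higher inhibition at most modest, and the expected step is a number 1 percentage points higher from compound 3 to compound 4 (within the scatter). Compound 4 is estimated at 56%, within 43% to 69%.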

Compound 4, a percentage reported as inhibition, at one concentration (the size of the read-out at that concentration, not a potency): 47.5%
Beside the measured number, compound 4's estimate is 8.5 percentage points above it; low and high end bracket the measured number.
By their numbers in this assay, from the lowest: compounds 2, 4, 3 and 1 (each within the scatter of the next, the first and the last beyond it).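

The step from 2,4-dimethoxyphenyl to 4-methoxyphenyl is a number 7.5 percentage points lower from compound 3 to compound 4 (within the scatter), and the step from 3-methoxyphenyl to 4-methoxyphenyl is a number 4.5 percentage points higher from compound 2 to compound 4 (within the scatter), so in this assay neither step separates these methoxy patterns. Against the unsubstituted phenyl, a single methoxy gives a number 10.5 percentage points lower from compound 1 to compound 4 (beyond the scatter), in line with compound 2, while compound 3, with two methoxy groups, goes against this pattern. The methoxy added at this position therefore does not read the same from every starting compound: the same change on two cores in this assay, a number 15 percentage points lower (beyond the scatter) from compound 1 to compound 2 and a number 7.5 percentage points higher (within the scatter) from compound 4 to compound 3, 22.5 percentage points apart, beyond the scatter of two such steps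

From the compounds shown here alone, what an amine or a carboxylic acid in place of methoxy on this aromatic carbon would do remains open. Going by these compounds, a longer chain, such as ethoxy, remains equally open.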